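The source may hold more compounds than are shown below. What is called first, only, known or untested is meant among the compounds shown, and "the series" means these compounds.

Measured so far in an in vitro assay on HEK-tsA201 cells for antagonist activity at Neuronal acetylcholine receptor; alpha3/beta4 (Homo sapiens), read by fluorescence and calcium flux; a lower number here means a stronger inhibitor, a higher number a weaker inhibitor:
Compound 1 `C=C(C)COc1ccc(C(=O)Nc2cccc(C)n2)cc1` gives 24700 nM.
Compound 2 `CCCOc1ccc(C(=O)Nc2cccc(Br)n2)cc1` gives > 100000 nM, which is a limit of the assay rather than a number.
Compound 3 `CCCOc1ccc(C(=O)Nc2cnccn2)cc1` gives 22500 nM.

Compound 2 therefore stands at the edge of what this assay can report: its result is described by the limit of > 100000 nM in this assay, at which 1 of the 3 values shown sits, and nothing finer is known about it. The change that leads from compound 2 to compound 4 `CCCOc1ccc(C(=O)Nc2cccc(Nc3ccc(Cl)cc3)n2)cc1` is (4-chlorophenyl)amino in place of bromo on an aromatic carbon. Within the data shown here, no two measured compounds differ in only one place, so the size of such a step cannot be read from the data, and the direction is open. Compound 1 gives 24700 nM and compound 3 gives 22500 nM, both of them numbers rather than limits. On that footing compound 4 is expected to give a number as well, estimated at 30000 nM, with a range from 6000 nM to 100000 nM. The step from compound 2 to compound 4 is expected to be an at least 3.3-fold lower number from compound 2 to compound 4 (0.52 log units; beyond the scatter), a move back toward measurable inhibition, though a limit for compound 4 cannot be ruled out.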

Compound 4, half-maximal inhibitory concentration: > 100000 nM
Compound 4 was reported as a limit (the forecaster's own chance of this, stated with the estimate: 30%); middle value at least 3.3-fold (0.52 log units) away from the limit.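

No step can be read between compound 2 and compound 4, because each result is a limit of the assay and not a number: the limit of > 100000 nM in this assay, at which 2 of the 4 values shown sit.

The compounds shown leave open whether (4-chlorophenyl)amino in place of bromo changes inhibition at all, and in which direction.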